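Trimming One Methyl from a Dimethylamino Group

The compounds below may be only part of what the source reports. "The series", "measured", "known", "first", "only" and "open" are said of these compounds alone.

Compound 1, `CC(=O)Nc1nc2ccccn2c1-c1ccc(O)cc1`: in an assay on isolated protein for inhibition of ubiquitin carboxyl-terminal hydrolase 14 (Homo sapiens) (on this read-out higher numbers stand for weaker inhibition and lower numbers for stronger inhibition), compound 1 gives > 100000 nM, a limit of the assay rather than a number.
Compound 2, `Nc1nc2ccccn2c1-c1ccc(O)cc1`: in this assay compound 2 gives > 100000 nM, again a limit.
Compound 3, `CN(C)c1nc2ccccn2c1-c1ccc(O)cc1`: in this assay compound 3 gives > 100000 nM, also a limit.

Compound 3 therefore stands where every measured compound stands, at the limit described by the limit of > 100000 nM in this assay, at which 3 of the 3 values shown sit. The unmeasured compound 4, `CNc1nc2ccccn2c1-c1ccc(O)cc1`, differs from compound 3 by hydrogen in place of methyl on a nitrogen on an aromatic ring, so it sits between compound 2 and compound 3 in the number of methyl groups on that nitrogen.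

Among the measured compounds shown here, three measured steps bear on this change. The step that the two limits leave unreadable from compound 2 to compound 3 spans exactly the methylamino group of compound 4, while a step that the two limits leave unreadable from compound 1 to compound 3 and a step that the two limits leave unreadable from compound 1 to compound 2 share the same end point at compound 3 or compound 2. None of these can be read as a size, because each end rests on the limit (the limit of > 100000 nM in this assay, at which 3 of the 3 values shown sit). No direction can be inferred, and no step beyond the scatter is expected; the estimated step that the limit leaves unreadable from compound 3 to compound 4 simply says compound 4 is expected to remain at the limit as well.

In this assay compound 4 is expected to give 150000 nM, with a range from 50000 nM to 500000 nM.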

Compound 4, half-maximal inhibitory concentration: > 100000 nM
Compound 4: no number, only a limit (the forecaster's own chance of this, stated with the estimate: 90%); the middle value is on the limit's open side.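

In this assay, compound 4 joins compound 1, compound 2 and compound 3 without a number, so no step among these compounds can be read: the limit of > 100000 nM in this assay, at which 4 of the 4 values shown sit.

The compounds shown leave open whether swapping hydrogen, methyl or acetyl on this nitrogen changes inhibition at all, and what a readable value for any of them would be.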